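The source may hold more compounds than are shown below. What is called first, only, known or untested is meant among the compounds shown, and "the series" means these compounds.

Measured compounds in the series:

- compound 1, `N/C(=N\O)c1ccc(C2=C(S(=O)(=O)c3ccc(Nc4ccccc4/C(N)=N/O)cc3)CC(c3ccccc3)(c3ccccc3)O2)cc1`: > 50000 nM (a limit, not a number)
- compound 2, `CC1(Cc2ccccc2)CC(S(=O)(=O)c2ccc(/C(N)=N/O)cc2)=C(c2ccc(Nc3ccccc3/C(N)=N/O)cc2)O1`: 48100 nM
- compound 3, `N/C(=N\O)c1ccc(/C=C/c2ccc(S(=O)(=O)C3=C(c4ccc(/C(N)=N/O)cc4)OC(c4ccccc4)(c4ccccc4)C3)cc2)cc1`: > 10000 nM (a limit, not a number)

In an ADME assay on THP-1 cells (Homo sapiens) for cytotoxicity, read by flow cytometry, with a stated time of 72 h (a higher number here means a weaker inhibitor, a lower number a stronger inhibitor), compound 1 returns only the limit > 50000 nM. Compound 3 likewise gives only the limit > 10000 nM in this assay. Going by the values given here, compound 2 is the one member with a number, 48100 nM in this assay.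

The change from compound 1 to compound 3 is a group of 12 heavy atoms (9 carbon, 2 nitrogen, 1 oxygen; one six-membered aromatic ring of carbon only) in place of a group of 11 heavy atoms (7 carbon, 3 nitrogen, 1 oxygen; one six-membered aromatic ring of carbon only), on an aromatic carbon. Its size, a step that the two limits leave unreadable from compound 1 to compound 3, cannot be read, because both ends are limits: the limit of > 50000 nM in this assay, at which 1 of the 3 values shown sits, for compound 1 and the limit of > 10000 nM in this assay, at which 1 of the 3 values shown sits, for compound 3. The difference between the cores of compound 1 and compound 2 is not broken down here.

Compound 4, `CC1(Cc2ccccc2)CC(S(=O)(=O)c2ccc(/C(N)=N/O)cc2)=C(c2ccc(/C=C/c3ccc(/C(N)=N/O)cc3)cc2)O1`, is not yet measured. It stands to compound 2 as compound 3 stands to compound 1: a group of 12 heavy atoms (9 carbon, 2 nitrogen, 1 oxygen; one six-membered aromatic ring of carbon only) in place of a group of 11 heavy atoms (7 carbon, 3 nitrogen, 1 oxygen; one six-membered aromatic ring of carbon only), on an aromatic carbon. The place lines of the two changes are identical, so this is the same change on a different core.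

With the earlier step unreadable, the expectation for compound 4 leans on compound 2 alone, whose value 48100 nM in this assay is the only number shown. The step from compound 2 to compound 4 is therefore expected to be small, a 1.1-fold lower number from compound 2 to compound 4 (0.03 log units; within the scatter), and a limit rather than a number is a real possibility. Compound 4 is estimated at 45000 nM in this assay, within 15000 nM to 120000 nM.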

Compound 4, half-maximal inhibitory concentration: 23400 nM
Beside the measured number, compound 4's estimate is 1.9-fold (0.28 log units) above it, and the stated range covers the measured number.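

In this assay the exchange of the 11-atom group for the 12-atom group, on an aromatic carbon para to a large group, gives a 2.1-fold lower number from compound 2 to compound 4 (0.31 log units; beyond the scatter) and so counts as a modest change on this one core. The same exchange on the core of compound 1 cannot be read, so nothing shows that the step carries from one core to the other, and neither its size nor its direction there is known; compound 1 is a limit and not a number: the limit of > 50000 nM in this assay, at which 1 of the 4 values shown sits.
Compound 3 is likewise a limit and not a number: the limit of > 10000 nM in this assay, at which 1 of the 4 values shown sits.

Open, going by these compounds, is whether the step returns on a further core with numbers at both ends, since one readable pair cannot establish a trend. Also open, on these data alone, is how a carboxylic acid or a nitrile in place of the amidoxime of the entering group, or a longer chain within that group, would read in this assay on either core.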